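A few compounds are considered here, and "the series" means these few. Any claim that something is new, unique, unknown or untested is made for them only; others in the source may bear on it.

Compound 1 `C/C(=C\CC/C(C)=C/CC[C@@H]1[C@@]2(C)CCC(=O)C(C)(C)[C@H]2CC[C@@]1(C)O)CC/C=C(\C)C(=O)OCc1cn(-c2cccc([N+](=O)[O-])c2)nn1`, compound 2 `C/C(=C\CC/C(C)=C/CC[C@@H]1[C@@]2(C)CCC(=O)C(C)(C)[C@H]2CC[C@@]1(C)O)CC/C=C(\C)C(=O)OCc1cn(-c2cccc(Br)c2)nn1` and compound 3 `C/C(=C\CC/C(C)=C/CC[C@@H]1[C@@]2(C)CCC(=O)C(C)(C)[C@H]2CC[C@@]1(C)O)CC/C=C(\C)C(=O)OCc1cn(-c2ccccc2Cl)nn1` share one core and differ only in the aromatic group on an aromatic nitrogen. In a functional assay on A549 cells (Homo sapiens) for antiproliferative activity, read by MTT assay, with a stated time of 48 h (on this read-out lower numbers stand for stronger inhibition and higher numbers for weaker inhibition), compound 1 gives > 150000 nM, which is a limit and not a number. Compound 2 gives > 150000 nM, also a limit. Compound 3 gives > 150000 nM, again a limit. All three stand at one place: the limit of > 150000 nM in this assay, at which 3 of the 3 values shown sit.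

Compound 4 `C/C(=C\CC/C(C)=C/CC[C@@H]1[C@@]2(C)CCC(=O)C(C)(C)[C@H]2CC[C@@]1(C)O)CC/C=C(\C)C(=O)OCc1cn(-c2cccc(O)c2)nn1` brings one change: 3-hydroxyphenyl in place of 2-chlorophenyl on an aromatic nitrogen, that is, 3-hydroxyphenyl in place of 2-chlorophenyl. The closest evidence is a step that the two limits leave unreadable from compound 1 to compound 2, a step that the two limits leave unreadable from compound 1 to compound 3 and a step that the two limits leave unreadable from compound 2 to compound 3. None of these sizes can be read, so they point in no direction. The expected change is a number no higher from compound 3 to compound 4 (the limit leaves the size open), with no firm direction. Compound 4 is expected near 150000 nM, with an estimated range of 50000 nM to 300000 nM.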

Compound 4, half-maximal inhibitory concentration: 42800 nM
Compound 4: the middle estimate sits 3.5-fold (0.54 log units) above what was measured; the measured number lies below the stated range.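

For the compounds shown here, the aromatic group on this nitrogen can move activity in this assay, which the earlier compounds could not show, as the steps among them cannot be read. Hydroxy in place of nitro gives an at least 3.5-fold lower number from compound 1 to compound 4 (0.54 log units; beyond the scatter), and hydroxy in place of bromo gives an at least 3.5-fold lower number from compound 2 to compound 4 (0.54 log units; beyond the scatter), while 3-hydroxyphenyl in place of 2-chlorophenyl gives an at least 3.5-fold lower number from compound 3 to compound 4 (0.54 log units; beyond the scatter). Only compound 4 leaves the shared limit: the limit of > 150000 nM in this assay, at which 3 of the 4 values shown sit.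

Going by these compounds, it remains open whether a 3-aminophenyl or 3-methoxyphenyl group would also leave that limit. The compounds shown also leave open how a 2-hydroxyphenyl group would compare.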